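Removing the Isopropyl Group from Compound 2

The source may hold more compounds than are shown below. What is called first, only, known or untested is meant among the compounds shown, and "the series" means these compounds.

In a functional assay on CH1 cells (Homo sapiens) for cytotoxicity (a lower number here means a stronger inhibitor, a higher number a weaker inhibitor), compound 1 `C[C@@]1([C@H](OC(=O)c2ccccc2)C(N)=O)CO1` gives > 25000 nM, which is a limit of the assay and not a number. Going by the values given here, compound 2 `CCOC(=O)[C@@H](NC(=O)[C@@H](OC(=O)c1ccc(C)c2cc(OC)ccc12)[C@]1(C)CO1)C(C)C` gives 315 nM, the only actual number so far. Compound 3 `CCOC(=O)CNC(=O)[C@@H](OC(=O)c1ccc(C)c2cc(OC)ccc12)[C@]1(C)CO1` differs through hydrogen in place of isopropyl on a saturated chain carbon bound to an amide-type nitrogen and a carbonyl carbon. Among the compounds with values here, no measured pair shows this change, so the expectation is tentative. A modest weakening in this assay is expected, with the estimated step of a 2.2-fold higher number from compound 2 to compound 3 (0.35 log units; beyond the scatter). For compound 3 the estimated value is 700 nM, with an expected range from 170 nM to 3000 nM.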

Compound 3, half-maximal inhibitory concentration: 260 nM
The estimate for compound 3 lay 2.7-fold (0.43 log units) above the measured number, and the stated range covers the measured number.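

The step of a 1.2-fold lower number from compound 2 to compound 3 (0.08 log units; within the scatter) in this assay shows that hydrogen in place of isopropyl, on a saturated chain carbon bound to an amide-type nitrogen and a carbonyl carbon, leaves the read-out unmoved. The isopropyl group is therefore not needed at this position to hold the value of compound 2. Nothing shown here gives a cause for this result.

Going by these compounds, whether a larger group on this carbon, such as benzyl, or an amine would also leave the value unmoved remains open.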